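A Methyl Added to Compound 2

This account rests on a few compounds, and the source may have more. Where it says the series, first, only, none or still open, it means among the compounds named here.

For the measured compounds named here, in an ADME assay on microsomes from liver (Homo sapiens) for metabolic stability (on this read-out lower numbers stand for a shorter-lived compound and higher numbers for a longer-lived compound), compound 1 `CN1C(=O)COc2cc(Nc3cc4c(cc3OC(F)(F)F)ncn4CC3CC3)cnc21` gives 0.167 h, while compound 2 `CN1C(=O)COc2cc(Nc3cc4c(cc3F)ncn4CC3CC3)cnc21` gives 0.533 h, the higher of the two numbers so far. Compound 3 `Cc1c(F)c(Nc2cnc3c(c2)OCC(=O)N3C)cc2c1ncn2CC1CC1` has not yet been measured. It differs from compound 2 by one small change: methyl in place of hydrogen on an aromatic carbon. In words, a methyl takes the place of a hydrogen on an aromatic carbon, ortho to a fluoro group. Going by the values given here, only one measured step can serve as a guide, a 3.2-fold higher number from compound 1 to compound 2 (0.50 log units; beyond the scatter), a modest move beyond the usual scatter. That step exchanged trifluoromethoxy for fluoro, so it gives a sense of size but no direction for a methyl. No step beyond the scatter is therefore expected in this assay, and the estimated change is a 1.1-fold lower number from compound 2 to compound 3 (0.05 log units; within the scatter). Compound 3 is expected at about 0.48 h, within an estimated range of 0.2 h to 1 h.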

Compound 3, half-life: 0.65 h
Beside the measured number, compound 3's estimate is 1.4-fold (0.13 log units) below it; the measured number falls inside the stated range.
By their numbers in this assay, from the lowest: compound 1; then compounds 2 and 3 (each within the scatter of the next).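

In this assay a methyl in place of hydrogen on this aromatic carbon, ortho to a fluoro group, gives a 1.2-fold higher number from compound 2 to compound 3 (0.09 log units; within the scatter) and so cannot be told apart from no change at all. For the compounds shown here, the only earlier step, a 3.2-fold higher number from compound 1 to compound 2 (0.50 log units; beyond the scatter) at the fluoro group's own carbon, showed that a swap on this ring can move the half-life beyond the scatter, whereas this position takes a methyl without any such move. Nothing available explains why the half-life holds here.

On these data alone, whether an ethyl, a methoxy or an amine on the same carbon would also leave the half-life in place remains open. As far as these compounds go, it is also open whether the methyl would behave the same way with trifluoromethoxy in place of the fluoro group, as in compound 1.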